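A few compounds are considered here, and "the series" means these few. Any claim that something is new, unique, unknown or untested is made for them only; others in the source may bear on it.

Compound 1 `C[C@@H]1CN(C(=O)c2nc(Nc3cc(C4CC4)[nH]n3)c3cc(Cl)ccc3n2)CCN1C(=O)OCc1ccccc1`: 4.4%
Compound 2 `CCCCCOC(=O)N1CCN(C(=O)c2nc(Nc3cc(C4CC4)[nH]n3)c3cc(Cl)ccc3n2)C[C@H]1C`: -3.8%

In an assay for inhibition of serine/threonine-protein kinase PAK 4 (Homo sapiens), read by FRET and Z'-LYTE, with a stated time of 60 min, tested at 0.5 uM, in the presence of a further agent that is not named here (on this read-out higher numbers stand for a stronger effect at the one concentration tested and lower numbers for a weaker effect), compound 1 gives 4.4% and compound 2 gives -3.8%. Compound 2 stands lowest of the two numbers, with compound 1 nearest, and the step of a number 8.2 percentage points lower from compound 1 to compound 2 (within the scatter) lies within the scatter. Compound 3 `COC(=O)N1CCN(C(=O)c2nc(Nc3cc(C4CC4)[nH]n3)c3cc(Cl)ccc3n2)C[C@H]1C` differs from compound 2 by hydrogen in place of butyl on a saturated chain carbon bound to an oxygen next to a carbonyl group. For the measured compounds named here, the only measured step, a number 8.2 percentage points lower from compound 1 to compound 2 (within the scatter), altered this same group without a shift beyond the scatter, so the expected step is a number 3.8 percentage points higher from compound 2 to compound 3 (within the scatter), none beyond the scatter. Compound 3 is therefore estimated at 0%, within -12% to 12%.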

Compound 3, a percentage reported as inhibition, at one concentration (the size of the read-out at that concentration, not a potency): 73.9%
Estimate against measurement, compound 3: 73.9 percentage points below, outside the stated range (above it).
By their numbers in this assay, from the lowest: compounds 2 and 1 (each within the scatter of the next); then compound 3.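

Going from pentyloxycarbonyl to methoxycarbonyl gives a number 77.7 percentage points higher from compound 2 to compound 3 (beyond the scatter), and hydrogen in place of phenyl at the same place gives a number 69.5 percentage points higher from compound 1 to compound 3 (beyond the scatter). This position therefore responds strongly to what sits on the saturated chain carbon bound to an oxygen next to a carbonyl group, even though butyl and phenyl there gave values within the scatter of each other. Nothing in the data at hand explains this jump.

The compounds shown leave open how an ethyl or propyl chain would read between these extremes. They also leave open what an amine or a carboxylic acid on this chain would do.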